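Anilide series on the shared core: cytotoxicity notes

The compounds below may be only part of what the source reports. "The series", "measured", "known", "first", "only" and "open" are said of these compounds alone.

Compound 1, `O=C(Nc1ccccc1)c1c(NO)cc(-c2cccs2)oc1=O`, is the reference point. In an ADME assay on Huh-7 cells (Homo sapiens) for cytotoxicity, with a stated time of 3 days (a higher number here means that more compound is tolerated, a lower number that less compound is tolerated), compound 1 gives > 20000 nM, which is a limit of the assay rather than a number. Compound 2, `O=C(Nc1ccc(Br)cc1)c1c(NO)cc(-c2cccs2)oc1=O`, carries bromo in place of hydrogen on an aromatic carbon; in this assay compound 2 gives > 20000 nM, again a limit. Compound 3, `Cc1ccc(NC(=O)c2c(NO)cc(-c3cccs3)oc2=O)cc1`, carries methyl in place of hydrogen on an aromatic carbon; in this assay compound 3 gives > 20000 nM, also a limit. Accordingly the steps a step that the two limits leave unreadable from compound 1 to compound 2, a step that the two limits leave unreadable from compound 1 to compound 3 and a step that the two limits leave unreadable from compound 2 to compound 3 cannot be sized, and the only firm point is the limit of > 20000 nM in this assay, at which 3 of the 3 values shown sit.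

Compound 4, `O=C(Nc1cccc(C(F)(F)F)c1)c1c(NO)cc(-c2cccs2)oc1=O`, differs from compound 1 by trifluoromethyl in place of hydrogen on an aromatic carbon. All three measured substituent changes on that ring, halogen or alkyl, left the readout at the limit, so no step beyond the scatter is expected from compound 1 to compound 4 in this assay; the expected step is a step that the limit leaves unreadable from compound 1 to compound 4. Compound 4 is therefore estimated at 30000 nM, between 12000 nM and 80000 nM, most probably reported again as a limit.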

Compound 4, half-maximal cytotoxic concentration: 11000 nM
The estimate for compound 4 lay 2.7-fold (0.44 log units) above the measured number, and the stated range ends above it.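

Compound 4, with trifluoromethyl on an aromatic carbon, meta to a large group, is the only compound shown that gives a number rather than a limit in this assay: the limit of > 20000 nM in this assay, at which 3 of the 4 values shown sit.

This change gives an at least 1.8-fold lower number from compound 1 to compound 4 (0.25 log units; that floor lies within the scatter). On these data alone, the floor of that step does not establish a fall beyond the scatter, and the full size stays unknown with compound 1 at a limit.

As far as these compounds go, it remains open whether the number for compound 4 follows from trifluoromethyl itself or from its place on the ring. Also open, from the compounds shown here alone, is what a nitrile, an amine or a carboxylic acid at this place would give in this assay.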